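The compounds below may be only part of what the source reports. "The series", "measured", "known", "first", "only" and "open" are said of these compounds alone.

Series notes. Compound 1 `CCCSc1nc(Cl)c2c(n1)N(Cc1ccccc1)C(C(=O)N1CCN(C(=O)OC(C)(C)C)CC1)N2` in a functional assay on TE-1 cells (Homo sapiens) for antiproliferative activity, read by MTT assay, with a stated time of 72 h (on this read-out lower numbers stand for stronger inhibition and higher numbers for weaker inhibition), gives 31200 nM. Compound 2 `CCCSc1nc(Cl)c2c(n1)N(Cc1ccccc1)C(C(=O)NCCNC(=O)OC(C)(C)C)N2` in this assay reaches only a limit of the assay, > 64000 nM. That limit is the limit of > 64000 nM in this assay, at which 1 of the 2 values shown sits, so compound 2 stands at the upper edge of the numbers shown, with no number of its own. Compound 3 `CCCSc1nc(Cl)c2c(n1)N(Cc1ccccc1)C(C(=O)N1CCN(C)CC1)N2` carries the change (4-methylpiperazin-1-yl in place of (2-((tert-butoxycarbonyl)amino)ethyl)amino on a carbonyl carbon). For the measured compounds named here, no measured step between compound 2 and compound 3 exists. The expected step of an at least 1.6-fold lower number from compound 2 to compound 3 (0.20 log units; that floor lies within the scatter) is a modest move toward stronger inhibition, not far beyond the usual scatter. Compound 3 is estimated at 40000 nM, with a range of 12000 nM to 90000 nM.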

Compound 3, half-maximal inhibitory concentration: 42500 nM
Estimate against measurement, compound 3: 1.1-fold (0.03 log units) below; low and high end bracket the measured number.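

On a carbonyl carbon, 4-methylpiperazin-1-yl gives a measured number in this assay, and the step reads an at least 1.5-fold lower number from compound 2 to compound 3 (0.17 log units; that floor lies within the scatter). Compound 2 has a limit of the assay, not a number: the limit of > 64000 nM in this assay, at which 1 of the 3 values shown sits.

On an amine nitrogen in a ring, the comparison gives a 1.4-fold higher number from compound 1 to compound 3 (0.13 log units; within the scatter), so methyl and tert-butoxycarbonyl are not told apart there. On these data alone, how far the step from compound 2 actually reaches stays open. Also open, as far as these compounds go, is whether a free amine hydrogen, an acetyl group or a longer alkyl chain on that nitrogen would move the number beyond the scatter.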